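The source may report more compounds than this note shows. Statements on the series, on what has been measured and on what is new or still open speak of the compounds shown alone.

Measured compounds:
compound 1, `O=C(O)Cc1sc(NCc2ccccc2)nc1-c1ccc(Cl)cc1`: 440 nM
compound 2, `O=C(O)Cc1sc(C(c2ccccc2)c2ccc(F)cc2)nc1-c1ccc(Cl)cc1`: 17 nM
compound 3, `O=C(O)Cc1sc(C(c2ccc(F)cc2)c2ccc(F)cc2)nc1-c1ccc(Cl)cc1`: 9.7 nM

In an in vitro assay on HEK385-7 cells for displacement of a labelled ligand from prostaglandin D2 receptor 2 (Homo sapiens) (on this read-out higher numbers stand for weaker inhibition and lower numbers for stronger inhibition), compound 3 gives 9.7 nM, the lowest of the three numbers, although the step of a 1.8-fold lower number from compound 2 to compound 3 (0.24 log units; within the scatter) lies within the scatter, so compound 2 and compound 3 cannot be set apart. Compound 1 with 440 nM stands far above both, beyond the scatter.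

Compound 4, `CN(C)c1cc(-c2nc(C(c3ccc(F)cc3)c3ccc(F)cc3)sc2CC(=O)O)ccn1`, is not yet measured. It differs from compound 3 in one place: 2-(dimethylamino)pyridin-4-yl in place of 4-chlorophenyl on an aromatic carbon. For the measured compounds named here, the only measured step, a 1.8-fold lower number from compound 2 to compound 3 (0.24 log units; within the scatter), concerns a fluoro on one of the two aryl groups of the large group and says nothing about the aryl group on the core that is exchanged here. Going by the values given here, no measured step bears on this change, so its size and direction are unknown; the expectation is therefore a step of no more than the scatter, with a wide range to either side, and compound 4 is expected to give about 15 nM, between 4 nM and 60 nM, which means a 1.5-fold higher number from compound 3 to compound 4 (0.19 log units; within the scatter) as the expected step.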

Compound 4, half-maximal inhibitory concentration: 380 nM
Compound 4: middle estimate off by 25-fold (1.40 log units), on the low side; measured number outside the range, above it.
By their numbers in this assay, from the lowest: compounds 3 and 2 (each within the scatter of the next); then compounds 4 and 1 (each within the scatter of the next).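

For the compounds shown here, the aryl position on the shared core, next to the ring nitrogen, held 4-chlorophenyl in all the earlier compounds, so its influence could not be seen until now. In this assay, placing 2-(dimethylamino)pyridin-4-yl there gives a 39-fold higher number from compound 3 to compound 4 (1.59 log units; beyond the scatter), a step beyond the scatter, which shows that the large group of compound 3 does not by itself secure a low number. Nothing available gives a reason for this step.

The ring nitrogen and the dimethylamino group enter together, so it stays open which of them accounts for the step; a plain pyridin-4-yl or a 3-(dimethylamino)phenyl group would separate the two. On these data alone, it also stays open whether the same exchange has a step of similar size with the large group of compound 2.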